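This account rests on a few compounds, and the source may have more. Where it says the series, first, only, none or still open, it means among the compounds named here.

Three compounds have been measured in a functional assay on cells (Cancer cell lines, Homo sapiens) for inhibition; a higher number here means a weaker inhibitor of growth, a lower number a stronger inhibitor of growth:

Compound 1, `N#CSc1c(-c2ccccc2)nc2sc(Cc3ccccc3)nn12`: 70800 nM
Compound 2, `COc1ccc(-c2nc3sc(Cc4ccccc4)nn3c2SC#N)cc1`: 70800 nM
Compound 3, `O=Cc1c(-c2ccc([N+](=O)[O-])cc2)nc2sc(Cc3ccccc3)nn12`: 58900 nM

Compound 3 has the lowest of the three numbers, but its value sits within the scatter of both compound 1 and compound 2, so the three compounds cannot be told apart on this assay. Among the measured compounds shown here, the one step available between measured compounds, no change at the digits printed from compound 1 to compound 2 (within the scatter), concerns a different position and different groups from the change now in question, so no measured step speaks directly to it.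

Compound 4, `O=[N+]([O-])c1ccc(-c2nc3sc(Cc4ccccc4)nn3c2Br)cc1`, differs from compound 3 in one place: bromo in place of formyl on an aromatic carbon. Both groups are small and sit on the shared core, and the measured compounds show a flat picture across unrelated changes, so no step beyond the scatter is expected in this assay, in either direction. Compound 4 is therefore estimated at 55000 nM, within a range of 15000 nM to 200000 nM, which amounts to an expected step of a 1.1-fold lower number from compound 3 to compound 4 (0.03 log units; within the scatter).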

Compound 4, concentration for total growth inhibition: 64600 nM
Beside the measured number, compound 4's estimate is 1.2-fold (0.07 log units) below it, and the stated range covers the measured number.
By their numbers in this assay, from the lowest: compounds 3, 4, 1 and 2 (each within the scatter of the next).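

In this assay, the step is a 1.1-fold higher number from compound 3 to compound 4 (0.04 log units; within the scatter) when bromo replaces formyl on this aromatic carbon of the five-membered ring. Among the compounds shown here, this is the first measured step at this position, and the earlier step concerned methoxy on a different ring. Here a group of 2 heavy atoms with a hydrogen-bond acceptor and a double bond gives way to a single bromine with neither, yet the two compounds cannot be told apart in this test, and no separate measurement bears on this result.

The compounds shown leave open whether an amine, a carboxylic acid or a longer chain at this position would shift the number beyond the scatter. They also cannot tell whether a change elsewhere on the shared core would make this position matter.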